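A few compounds are considered here, and "the series" means these few. Any claim that something is new, unique, unknown or untested is made for them only; others in the source may bear on it.

Compound 1 `O=C(CCC(=O)OCCCCCCSc1ccc([N+](=O)[O-])c2nonc12)Nc1ccccc1Cl` gives 335000 nM in a functional assay on HOS cells (Homo sapiens) for inhibition, read by MTT assay, with a stated time of 72 h; a lower number here means a stronger inhibitor, a higher number a weaker inhibitor.
Compound 2 `Cc1ccccc1NC(=O)CCC(=O)OCCCCCCSc1ccc([N+](=O)[O-])c2nonc12` gives 4020 nM in this assay.

Compound 2 has the lower of the two numbers, with compound 1 well above it. Compound 3 `O=C(CCC(=O)OCCCCCCSc1ccc([N+](=O)[O-])c2nonc12)Nc1cccc(Cl)c1` differs from compound 2 as follows: 3-chlorophenyl in place of 2-methylphenyl on an amide-type nitrogen. In short, 3-chlorophenyl stands in place of 2-methylphenyl on an amide-type nitrogen. Within the data shown here, the only measured step that bears on this is an 83-fold lower number from compound 1 to compound 2 (1.92 log units; beyond the scatter), a large step with methyl in place of chloro on an aromatic carbon. Among the measured compounds shown here, no 3-chlorophenyl example has been measured, so that step is only a loose guide. A higher number but a smaller step is therefore expected, an estimated 4.0-fold higher number from compound 2 to compound 3 (0.60 log units; beyond the scatter). For compound 3 the expected value is 16000 nM, with an estimated range of 3000 nM to 90000 nM.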

Compound 3, half-maximal inhibitory concentration: 1920 nM
Beside the measured number, compound 3's estimate is 8.3-fold (0.92 log units) above it, outside the stated range (below it).
By their numbers in this assay, from the lowest: compound 3; then compound 2; then compound 1.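

In this assay the change to 3-chlorophenyl on the amide-type nitrogen gives a 2.1-fold lower number from compound 2 to compound 3 (0.32 log units; beyond the scatter) as a modest step, so a chlorine-bearing phenyl at this place need not carry a high number. The change from 2-chlorophenyl gives a 170-fold lower number from compound 1 to compound 3 (2.24 log units; beyond the scatter) as a large step, so among these compounds the high number goes with 2-chlorophenyl and not with chloro as such. No evidence at hand explains either step.

The compounds shown leave open how an unsubstituted phenyl or a methoxyphenyl on this nitrogen would compare. They also leave open whether a longer chain between the amide and the ester would change these steps.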